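A few compounds are considered here, and "the series" means these few. Any claim that something is new, unique, unknown or untested is made for them only; others in the source may bear on it.

Compound 1, `COC(=O)C1=C(C)N=C(C)/C(=C(\O)OC)C1c1ccccc1Cl`: 2.19 nM
Compound 2, `COC(=O)C1=C(C)N=C(C)/C(=C(\O)OC)C1c1c(F)c(F)c(F)c(F)c1F`: 4.37 nM
Compound 3, `COC(=O)C1=C(C)N=C(C)/C(=C(\O)OC)C1c1cc([N+](=O)[O-])ccc1O`: 100 nM

These three compounds share one core and were tested in a functional assay (muscle tissue) with Cavia porcellus as the target; a higher number here means that more compound is needed for the effect, a lower number that less compound is needed. Compound 1 gives the lowest of the three numbers. Compound 2 sits close by, its value lying within the scatter of repeated measurements, so the two cannot be told apart. Compound 3 stands far higher, well beyond the scatter, and its different pattern of groups on the phenyl ring goes together with a much larger amount of compound needed.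

The next compound to be measured is compound 4, `COC(=O)C1=C(C)N=C(C)/C(=C(\O)OC)C1c1ccc(Br)cc1`. It differs from compound 1 in one place: 4-bromophenyl in place of 2-chlorophenyl on a saturated ring carbon. Going by the values given here, no measured pair in this set isolates such a change, so the direction and size of the step must be guessed from what is at hand. Compound 3, with 100 nM, shows that altering what sits on the phenyl ring can move the number well beyond the scatter. Compound 4 is therefore expected to need somewhat more compound, at about 20 nM, with a likely range from 5 nM to 100 nM. For compound 4 this amounts to an expected step of a 9.1-fold higher number from compound 1 to compound 4 (0.96 log units; beyond the scatter).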

Compound 4, half-maximal effective concentration: 540 nM
Beside the measured number, compound 4's estimate is 27-fold (1.43 log units) below it; measured number above the stated range.
By their numbers in this assay, from the lowest: compounds 1 and 2 (each within the scatter of the next); then compound 3; then compound 4.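

In this assay, going by these compounds alone, putting 4-bromophenyl in place of 2-chlorophenyl on the saturated ring carbon gives a 250-fold higher number from compound 1 to compound 4 (2.39 log units; beyond the scatter) and marks the first single change in this set that can be read directly. It shows that this position is far from indifferent to what the phenyl ring carries, even though the two groups match in number of heavy atoms, carry no hydrogen-bond donors or acceptors and have no net charge. Nothing measured here explains why the step is so large.

In this change the halogen and its place on the phenyl ring differ together, so the compounds shown cannot separate the two, whereas a phenyl ring carrying chlorine exactly where compound 4 carries bromine would begin to do so. Also open is how the number would respond to a phenyl ring bearing an amine, a carboxylic acid or a longer chain in place of the halogen, since none of the compounds shown carries such a group.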